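The compounds below may be only part of what the source reports. "The series", "measured", "known", "first", "only" and "open" are said of these compounds alone.

Compound 1: `C=CCn1c(=O)/c(=C\c2cccc(C)c2)[nH]c(=O)/c1=C\c1ccccc1OC`, 5100 nM in a functional assay on U-937 cells (Homo sapiens) for cytotoxicity, read by CCK-8 assay, with a stated time of 72 h; on this read-out higher numbers stand for weaker inhibition and lower numbers for stronger inhibition.
Compound 2: `C=CCn1c(=O)/c(=C\c2cccc(F)c2)[nH]c(=O)/c1=C\c1ccccc1OC`, 2500 nM.
Compound 3: `C=CCn1c(=O)/c(=C\c2ccccc2F)[nH]c(=O)/c1=C\c1ccccc1OC`, 5500 nM.

Compound 3 gives the highest of the three numbers, but its gap to compound 1 is within the scatter, so the two cannot be ordered; only compound 2 stands apart, as a 2.2-fold higher number from compound 2 to compound 3 (0.34 log units; beyond the scatter) shows. Going by the values given here, compound 4 is `C=CCn1c(=O)/c(=C\c2ccccc2C(F)(F)F)[nH]c(=O)/c1=C\c1ccccc1OC`. trifluoromethyl in place of fluoro on an aromatic carbon No measured step exchanges fluoro for trifluoromethyl. The nearest comparison is a 2.0-fold lower number from compound 1 to compound 2 (0.31 log units; beyond the scatter), where fluoro replaced methyl, but at another carbon and in the other direction of size, so it offers no direct guide. Among the compounds with values here, with no step bearing on the change, compound 4 is expected to sit close to compound 3, with no change at the digits printed from compound 3 to compound 4 (within the scatter) treated as a step not beyond the scatter. In this assay compound 4 is therefore estimated at 5500 nM, within a range from 2500 nM to 12000 nM.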

Compound 4, half-maximal inhibitory concentration: 1500 nM
Estimate against measurement, compound 4: 3.7-fold (0.56 log units) above; measured number below the stated range.
By their numbers in this assay, from the lowest: compounds 4 and 2 (each within the scatter of the next); then compounds 1 and 3 (each within the scatter of the next).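

In this assay, the carbon that carries fluoro in compound 3 proves responsive to the group placed on it, as a 3.7-fold lower number from compound 3 to compound 4 (0.56 log units; beyond the scatter) shows, and this is the only step shown that changes the group on this carbon alone. The 2-(trifluoromethyl)phenyl group also separates compound 4 from the 3-methylphenyl compound, with a 3.4-fold lower number from compound 1 to compound 4 (0.53 log units; beyond the scatter), while a 1.7-fold lower number from compound 2 to compound 4 (0.22 log units; within the scatter) leaves it inseparable from the 3-fluorophenyl compound, so a group at this place does not by itself tie a compound to the higher numbers. Nothing measured here accounts for the step from fluoro to trifluoromethyl.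

On these data alone, how an amine, a carboxylic acid or a nitrile on this same carbon would read remains open. Also open, as far as these compounds go, is whether trifluoromethyl would give a similar step on the carbon that bears fluoro in compound 2.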